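A few compounds are considered here, and "the series" means these few. Any claim that something is new, unique, unknown or untested is made for them only; others in the source may bear on it.

In a functional assay on the whole organism with Mus musculus as the target (a higher number here means that more compound is needed for the effect, a lower number that less compound is needed), compound 1 `O=C(OC1CCN(c2ccc(-c3ccccc3Cl)nn2)CC1)C1CC1` gives 92 mg/kg, and compound 2 `CNC(=O)OC1CCN(c2ccc(-c3ccccc3Cl)nn2)CC1` gives 13 mg/kg. Going by the values given here, compound 2 therefore holds the lower of the two numbers so far, meaning that less of it is needed for the effect. Compound 3 `CN(C)C(=O)OC1CCN(c2ccc(-c3ccccc3Cl)nn2)CC1` differs from compound 2 in one small detail: methyl in place of hydrogen on an amide-type nitrogen. In words, this puts methyl in place of hydrogen on an amide-type nitrogen, turning methylamino into dimethylamino. Among the compounds with values here, no measured pair shows this exact change, so the evidence is thin. Within the data shown here, only one measured step bears on it, and only indirectly: a 7.1-fold lower number from compound 1 to compound 2 (0.85 log units; beyond the scatter). That step also alters what sits on the carbonyl carbon, but it swaps a whole group rather than adding one methyl. A smaller step is therefore expected here. Among the measured compounds shown here, its direction is uncertain, although with only two measured numbers, a slight move back up from the lower one seems the likelier outcome. The estimated step is a 1.5-fold higher number from compound 2 to compound 3 (0.19 log units; within the scatter). For compound 3 the expected value is 20 mg/kg, with an estimated range of 7 mg/kg to 55 mg/kg.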

Compound 3, dose for half-maximal effect: 1.6 mg/kg
Estimate against measurement, compound 3: 13-fold (1.10 log units) above; measured number outside the range, below it.
By their numbers in this assay, from the lowest: compound 3; then compound 2; then compound 1.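

The amide-type nitrogen proves to be a sensitive place in this assay: methyl in place of the amide hydrogen, a single added heavy atom, gives an 8.1-fold lower number from compound 2 to compound 3 (0.91 log units; beyond the scatter) and so counts for far more than its small size would suggest. The amide hydrogen is therefore not needed for the effect in this assay, since compound 3 lacks it and has the lowest number of the three compounds. Compared with the cyclopropyl group on the carbonyl carbon, dimethylamino gives a 58-fold lower number from compound 1 to compound 3 (1.76 log units; beyond the scatter) and makes this the largest step so far, with each move from cyclopropyl to methylamino and then to dimethylamino lowering the dose needed.

The compounds shown leave open whether this trend continues with larger groups on the nitrogen, such as ethyl in place of one methyl or a diethylamino group, or whether dimethylamino is already the best fit. Also open is what lies behind the gain, as no measurement here speaks to it.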